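Adding a chain to compound 3 in growth inhibition

The compounds below may be only part of what the source reports. "The series", "measured", "known", "first", "only" and "open" are said of these compounds alone.

In a functional assay on MCF7 cells (Homo sapiens) for inhibition, read by MTT assay, with a stated time of 72 h (on this read-out lower numbers stand for stronger inhibition of growth and higher numbers for weaker inhibition of growth), compound 1 `CC(C)=CC(=O)NC(=N)N` gives > 100000 nM, which is a limit of the assay and not a number. For the measured compounds named here, only two compounds give true numbers. Compound 3 `CC(C)=CC(=O)NC(=N)NC(=O)C=C(C)C` stands higher at 59700 nM, and compound 2 `C=C1CCCC(C)(C)[C@@H]1CC/C(C)=C/C(=O)NC(=N)NC(=O)C=C(C)C` follows at 28100 nM, a gap beyond the scatter. Compound 3 therefore shows the weaker growth inhibition of this pair.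

The next compound to be tested is compound 4 `CC(C)=CCC/C(C)=C/C(=O)NC(=N)NC(=O)C=C(C)C`. It differs from compound 3 by 3-methylbut-2-en-1-yl in place of hydrogen on a saturated chain carbon bound to a double-bonded chain carbon, with 3-methylbut-2-en-1-yl in place of hydrogen on a saturated chain carbon bound to a double-bonded chain carbon. Going by the values given here, no measured step isolates such a change, so the guide is thin. It rests on compound 2, which has a larger group at that end of the molecule and reads 28100 nM. In this assay, the estimated 1.7-fold lower number from compound 3 to compound 4 (0.23 log units; within the scatter) is a small move towards a lower number, not expected to exceed the scatter. For compound 4 the expected value is 35000 nM, with an estimated range from 14000 nM to 80000 nM.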

Compound 4, concentration for 50% growth inhibition: 41500 nM
Estimate against measurement, compound 4: 1.2-fold (0.07 log units) below; measured number inside the range.
By their numbers in this assay, from the lowest: compounds 2, 4 and 3 (each within the scatter of the next, the first and the last beyond it). At a limit, above all of these: compound 1.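

In this assay, setting 3-methylbut-2-en-1-yl in place of hydrogen on a saturated chain carbon bound to a double-bonded chain carbon gives a 1.4-fold lower number from compound 3 to compound 4 (0.16 log units; within the scatter). For the compounds shown here, this is the first step measured at this position, and it shows that the position accepts this open chain while growth inhibition stays within the scatter of the unsubstituted compound, so the added chain alone gives no clear gain. Nothing among the data shown explains this small step.

The compounds shown leave open how a longer chain, an amine or a carboxylic acid at this position would read in this assay. They also leave open whether any group here can move the number beyond the scatter.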